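A few compounds are considered here, and "the series" means these few. Any claim that something is new, unique, unknown or untested is made for them only; others in the source may bear on it.

For the measured compounds named here, compound 3, with the structure `CCCCCc1cc(C(F)(F)F)ccc1CNC(=O)C(C)c1ccc(NS(C)(=O)=O)c(F)c1`, gives 0.4 nM in an assay on CHO cells for antagonist activity at transient receptor potential cation channel subfamily V member 1 (Homo sapiens), read by FLIPR (a lower number here means a stronger inhibitor, a higher number a weaker inhibitor), the lowest of the three numbers measured so far. Compound 1, `CC(C(=O)NCc1ccc(C(F)(F)F)cc1N1CCCC1)c1ccc(NS(C)(=O)=O)c(F)c1`, gives 2.3 nM, and compound 2, `CCCCSc1cc(C(F)(F)F)ccc1CNC(=O)C(C)c1ccc(NS(C)(=O)=O)c(F)c1`, gives 1.9 nM. The two steps leading to compound 3 are both modest and beyond the scatter: a 5.8-fold lower number from compound 1 to compound 3 (0.76 log units; beyond the scatter) and a 4.8-fold lower number from compound 2 to compound 3 (0.68 log units; beyond the scatter). The step between the other two, a 1.2-fold lower number from compound 1 to compound 2 (0.08 log units; within the scatter), lies within the scatter.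

Compound 4, `CC(C(=O)NCc1ccc(C(F)(F)F)cc1C1CCCCC1)c1ccc(NS(C)(=O)=O)c(F)c1`, differs from compound 3 by cyclohexyl in place of pentyl on an aromatic carbon. Of the measured steps, only those ending at compound 3 change the same position, and neither involves a cyclohexyl group, so they bear on the new step only indirectly. They show that exchanging the group at this position moves the number by modest amounts at most. Compound 4 is therefore expected to stay close to compound 3, with a small shift toward a higher number as the more likely direction, meaning an estimated step of a 1.8-fold higher number from compound 3 to compound 4 (0.24 log units; within the scatter). The estimate for compound 4 is 0.7 nM, within the range 0.2 nM to 2.5 nM.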

Compound 4, inhibition constant: 0.6 nM
Estimate against measurement, compound 4: 1.2-fold (0.07 log units) above, and the stated range covers the measured number.
By their numbers in this assay, from the lowest: compounds 3 and 4 (each within the scatter of the next); then compounds 2 and 1 (each within the scatter of the next).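

In this assay, cyclohexyl in place of pentyl gives a 1.5-fold higher number from compound 3 to compound 4 (0.18 log units; within the scatter), so at this position a six-membered non-aromatic ring of carbon only and an open pentyl chain cannot be told apart. Cyclohexyl in place of butylsulfanyl gives a 3.2-fold lower number from compound 2 to compound 4 (0.50 log units; beyond the scatter), and cyclohexyl in place of pyrrolidin-1-yl gives a 3.8-fold lower number from compound 1 to compound 4 (0.58 log units; beyond the scatter), so among these four compounds the two all-carbon groups, pentyl and cyclohexyl, both give lower numbers than butylsulfanyl and pyrrolidin-1-yl, and no compound shown goes against this. No measurement at hand explains these differences.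

The compounds shown leave open how a cyclopropyl group, a phenyl ring or a chain ending in an amine would read at this position. They also leave open whether a longer chain, such as octyl, would stay level with pentyl and cyclohexyl.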